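This account rests on a few compounds, and the source may have more. Where it says the series, first, only, none or still open, it means among the compounds named here.

Compound 1 `COC(=O)C(c1ccccc1Cl)N1CCC(O)(Cn2cnc3c(cnn3-c3ccc(F)cc3)c2=O)CC1` gives "not determined" (no result reported) in an assay on Sf21 cells for inhibition of ubiquitin carboxyl-terminal hydrolase 7 (Homo sapiens), read by spectrophotometry, with stated times of 30 min and 2 h (on this read-out higher numbers stand for weaker inhibition and lower numbers for stronger inhibition), and compound 3 `N#Cc1ccc(CN2CCC(O)(Cn3cnc4c(cnn4-c4ccc(F)cc4)c3=O)CC2)cc1` gives "not determined" (no result reported) in this assay; for both no number was reported. Among the measured compounds shown here, compound 2 `O=c1c2cnn(-c3ccc(F)cc3)c2ncn1CC1(O)CCN(Cc2ccccc2Cl)CC1` gives 3400 nM in this assay, the only number in the set. Compound 3 thus stands without a number, and one further compound shares that gap. Compound 4 `O=c1c2cnn(-c3ccc(F)cc3)c2ncn1CC1(O)CCN(Cc2ccc(Br)cc2Cl)CC1` differs from compound 3 by 4-bromo-2-chlorophenyl in place of 4-cyanophenyl on a saturated chain carbon bound to an amine nitrogen in a ring. For the measured compounds named here, no step between measured compounds exists here, so no direction can be read from compound 3; the only anchor is the result of compound 2, and compound 4 is expected to sit in the same region, with no step beyond the scatter. Compound 4 is expected to give about 2500 nM in this assay, between 800 nM and 8000 nM.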

Compound 4, half-maximal inhibitory concentration: 1900 nM
Compound 4: the middle estimate sits 1.3-fold (0.12 log units) above what was measured; the range from low to high includes it.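

In this assay, among the compounds shown here, this is the first comparison with a number on both sides: bromo in place of hydrogen on an aromatic carbon gives a 1.8-fold lower number from compound 2 to compound 4 (0.25 log units; within the scatter). The benzyl group on the ring amine nitrogen therefore carries this bromo in compound 4 with a number in the same low-micromolar region as compound 2. No evidence is available on why this step is so small. Going by these compounds, whether an amine or a carboxylic acid in place of that bromo would also stay in this region remains open. So does the effect of a single substituent such as the nitrile of compound 3, which has no number.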